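This account rests on a few compounds, and the source may have more. Where it says the series, first, only, none or still open, it means among the compounds named here.

Of the compounds shown here, two sharing one core have been tested in an assay on membranes from brain for displacement of a labelled ligand from Sigma non-opioid intracellular receptor 1 (Cavia porcellus), read by scintillation counting, with a stated time of 120 min; a lower number here means a stronger inhibitor, a higher number a weaker inhibitor. Compound 1 `c1ccc(CN2CCC3(CC2)OCCc2cc(-c4ccccc4)sc23)cc1` carries an unsubstituted phenyl; in this assay compound 1 gives 2.4 nM. Compound 2 `COc1ccc(-c2cc3c(s2)C2(CCN(Cc4ccccc4)CC2)OC(OC)C3)cc1` carries a methoxy on that phenyl and a second methoxy on the core; in this assay compound 2 gives 56 nM. Compound 2 thus has the higher of the two numbers, and its gap to compound 1 lies beyond the usual scatter of the method.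

Compound 3 `COC1Cc2cc(-c3ccc(-c4ccccc4)cc3)sc2C2(CCN(Cc3ccccc3)CC2)O1` has not yet been measured. It differs from compound 2 in one place: phenyl in place of methoxy on an aromatic carbon. Among the compounds with values here, no measured pair shows this exact change, so its size cannot be read from the data. Because compound 1 gives 2.4 nM without any methoxy on its phenyl, a modest step toward a lower number is expected, a 1.6-fold lower number from compound 2 to compound 3 (0.20 log units; within the scatter). Compound 3 is therefore expected to give 35 nM, with a range from 8 nM to 150 nM.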

Compound 3, inhibition constant: 211 nM
The estimate for compound 3 lay 6.0-fold (0.78 log units) below the measured number; measured number above the stated range.
By their numbers in this assay, from the lowest: compound 1; then compound 2; then compound 3.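

Putting a phenyl in place of the methoxy on this aromatic carbon, para to a large group, gives in this assay a 3.8-fold higher number from compound 2 to compound 3 (0.58 log units; beyond the scatter). The two earlier compounds differ in two places, so they could not isolate this position; this step is its first direct reading, and it shows that adding a further aromatic ring here makes the compound a weaker inhibitor rather than a stronger one. Nothing measured here explains this shift.

With only methoxy and phenyl compared at this position, it remains unclear whether the trend depends on the size of the group or on something specific to the phenyl ring. From the compounds shown here alone, how a chlorine, an amine or a longer chain such as ethoxy would read at this position also remains open.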